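The compounds below may be only part of what the source reports. "The series", "measured", "known", "first", "only" and "open" are said of these compounds alone.

Measured compounds:
- compound 1 `CCOC(=O)CC1C(C(=O)OCC)=C(N)Oc2ccc(Br)cc21`: 57300 nM
- compound 2 `CCOCC1C(C#N)=C(N)Oc2ccc(-c3ccccc3)cc21`: 52500 nM
- compound 3 `CCOC(=O)C1=C(N)Oc2ccc(-c3ccccc3)cc2C1CC(=O)N1CCCCC1`: 58500 nM

All three values come from a functional assay on Jurkat cells (Homo sapiens) for cytotoxicity, with a stated time of 48 h; on this read-out lower numbers stand for stronger inhibition and higher numbers for weaker inhibition. Compound 1 stands level with compound 2 and compound 3, since the gaps among them lie within the scatter. Compound 4 `CCOC(=O)CC1C(C(=O)OCC)=C(N)Oc2ccc(-c3cc(O)cc(O)c3)cc21`, not yet measured, carries 3,5-dihydroxyphenyl in place of the bromo of compound 1 on an aromatic carbon (3,5-dihydroxyphenyl in place of bromo on an aromatic carbon). Among the compounds with values here, no measured pair differs in one place only, so the guide is indirect. Where compound 1 has bromo, compound 3 has a phenyl group and gives 58500 nM, though it differs elsewhere too. Only a small move towards stronger inhibition in this assay is therefore expected, possibly none beyond the scatter. The estimated change is a 1.6-fold lower number from compound 1 to compound 4 (0.21 log units; within the scatter). For compound 4 the expected value is 35000 nM, with an estimated range of 12000 nM to 90000 nM.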

Compound 4, half-maximal inhibitory concentration: 18300 nM
Estimate against measurement, compound 4: 1.9-fold (0.28 log units) above; the range from low to high includes it.
By their numbers in this assay, from the lowest: compound 4; then compounds 2, 1 and 3 (each within the scatter of the next).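

In this assay, within the data shown here, the aromatic carbon that holds bromo in compound 1 turns out to matter: placing 3,5-dihydroxyphenyl there gives a 3.1-fold lower number from compound 1 to compound 4 (0.50 log units; beyond the scatter) and provides the first comparison here between compounds that differ in one place only. The step is modest, yet it shows that this position tolerates a much larger group without loss of inhibition. Nothing available explains the shift.

On these data alone, whether the new ring or its two hydroxy groups drive the step remains open. So does how a plain phenyl, or a phenyl bearing an amine or a carboxylic acid, would compare at this position.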